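The source may hold more compounds than are shown below. What is called first, only, known or untested is meant among the compounds shown, and "the series" means these compounds.

In a functional assay on HCT-116 cells (Homo sapiens) for antiproliferative activity, read by MTT assay, with a stated time of 72 h (on this read-out higher numbers stand for weaker inhibition and lower numbers for stronger inhibition), compound 1 `NC1=NC2(CCSCC2)N(OCCCOc2cccc(Cl)c2)C(N)=N1` gives 1 nM and compound 3 `NC1=NC2(CCSCC2)N(OCCCOc2cccc(Cl)c2Cl)C(N)=N1` gives 1 nM. Compound 2 `NC1=NC2(CCOCC2)N(OCCCOc2ccc(F)cc2)C(N)=N1` gives 3280 nM, the highest number of the three and well beyond the usual scatter from both others. Compound 4 `NC1=NC2(CCOCC2)N(OCCCOc2cccc(Cl)c2)C(N)=N1` keeps the core of compound 2 and alters only the group at the end of the chain: 3-chlorophenyl in place of 4-fluorophenyl on an oxygen on a saturated carbon. In words, this is 3-chlorophenyl in place of 4-fluorophenyl on an oxygen on a saturated carbon.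

Within the data shown here, only one measured step bears directly on that aromatic group, and it shows no change at the digits printed from compound 1 to compound 3 (within the scatter), with chloro in place of hydrogen on an aromatic carbon. It does not involve the fluoro group, and it sits on the other core. Compound 1, at 1 nM, already carries the entering group, but its core differs from that of compound 4. The data do not show how much of the gap belongs to the aromatic group and how much to the core. A clear drop, though not the whole gap, is therefore expected in this assay. The estimated change is a 55-fold lower number from compound 2 to compound 4 (1.74 log units; beyond the scatter). Compound 4 is estimated at 60 nM, with an expected range from 3 nM to 1500 nM.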

Compound 4, half-maximal inhibitory concentration: 120 nM
Compound 4: the middle estimate sits 2.0-fold (0.30 log units) below what was measured; measured number inside the range.
By their numbers in this assay, from the lowest: compounds 1 and 3 (each within the scatter of the next); then compound 4; then compound 2.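

With the core held fixed, the end group of the chain matters on its own in this assay: exchanging 4-fluorophenyl for 3-chlorophenyl gives a 27-fold lower number from compound 2 to compound 4 (1.44 log units; beyond the scatter). Among these compounds, the earlier step on the aromatic ring showed no change on the core of compound 1, so this large shift is the first sign that the ring's substitution can move the number. The swap does not close the gap to the other core, as compound 4 stands at 120 nM and compound 1, with the same end group, at 1 nM, and nothing measured here explains the shift.

This step changes the halogen and its place on the ring together, leaving the contribution of each unresolved. From the compounds shown here alone, how a plain phenyl or a methoxy-bearing phenyl would behave on this core also remains open.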